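The compounds below may be only part of what the source reports. "The series", "measured", "known", "first", "only" and "open" are said of these compounds alone.

Measured compounds in an ADME assay on HepG2 cells (Homo sapiens) for cytotoxicity, read by luminescence, CellTiter-Glo and ATP content, with a stated time of 72 h; a higher number here means that more compound is needed for the effect, a lower number that less compound is needed:
compound 1, `COc1cccc(CNCCCNc2ccnc3cc(Cc4ccc(C#N)cc4)ccc23)c1O`, 7150 nM
compound 2, `COc1cccc(CNCCCNc2ccnc3cc(-c4ccc(F)cc4)ccc23)c1O`, 6840 nM
compound 3, `COc1ccccc1Oc1ccc2c(NCCCNCc3cccc(OC)c3O)ccnc2c1`, 11200 nM

Compound 1 holds the second highest of the three numbers. Its nearest neighbour is compound 2, a 1.0-fold lower number from compound 1 to compound 2 (0.02 log units; within the scatter); its furthest is compound 3, a 1.6-fold higher number from compound 1 to compound 3 (0.19 log units; within the scatter). The remaining pair, a 1.6-fold higher number from compound 2 to compound 3 (0.21 log units; within the scatter), is likewise within the scatter. Each of these steps exchanges the group on an aromatic carbon of the shared core, and none of them moves the number beyond the scatter, so on present evidence the read-out in this assay is flat across this end of the molecule.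

Compound 4, `N#Cc1ccc(Cc2ccc3c(NCCCNCc4ccco4)ccnc3c2)cc1`, is the next to be measured. Relative to compound 1 the change is furan-2-yl in place of 2-hydroxy-3-methoxyphenyl on a saturated chain carbon bound to an amine nitrogen. Going by the values given here, no measured step touches this end of the chain: all three steps so far alter the group on the aromatic carbon, not the group on the saturated chain carbon bound to the amine nitrogen. They therefore bear on compound 4 only indirectly, by showing that the three compounds sit within scatter of one another whatever the exchange made. Among the compounds with values here, with no directional precedent, no step beyond the scatter is expected, and the number for compound 4 is estimated at 7000 nM, within 3500 nM to 14000 nM, an expected step of a 1.0-fold lower number from compound 1 to compound 4 (0.01 log units; within the scatter).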

Compound 4, half-maximal effective concentration: 7910 nM
Compound 4: middle estimate off by 1.1-fold (0.05 log units), on the low side; measured number inside the range.
By their numbers in this assay, from the lowest: compounds 2, 1, 4 and 3 (each within the scatter of the next).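

In this assay, going by these compounds alone, the step at this position (a 1.1-fold higher number from compound 1 to compound 4 (0.04 log units; within the scatter)) gives the first reading on a saturated chain carbon bound to an amine nitrogen, and the flat picture seen so far at the aromatic carbon extends to this second site, at least for this one exchange. The exchange is not a small one by the counts: 2-hydroxy-3-methoxyphenyl, with 9 heavy atoms, 1 hydrogen-bond donor and 2 hydrogen-bond acceptors, gives way to furan-2-yl, with 5 heavy atoms, 0 hydrogen-bond donors and 1 hydrogen-bond acceptor, so in this pair neither the six-membered ring nor its hydroxy and methoxy groups are needed to keep the number where it stands. No measurement at hand offers a reason for the result.

As far as these compounds go, the reading rests on a single pair carrying 4-cyanobenzyl on the aromatic carbon, so whether furan-2-yl behaves alike alongside 4-fluorophenyl or 2-methoxyphenoxy remains open. Also open is whether any group on this chain carbon, such as a carboxylic acid, a piperidine or a cyclohexyl ring, would move the number beyond the scatter, since every compound shown lies within the scatter of its neighbours.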